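This account rests on a few compounds, and the source may have more. Where it says the series, first, only, none or still open, it means among the compounds named here.

Among the measured compounds shown here, in a functional assay on HCT-116 cells (Homo sapiens) for inhibition, read by MTT assay, with a stated time of 72 h (on this read-out higher numbers stand for weaker inhibition of growth and lower numbers for stronger inhibition of growth), compound 1 `CNC(=O)/C=C/c1ccncc1-c1ccc2ccccc2c1` gives 6550 nM and is the only compound in this set with a number so far. Compound 2 `O=C(O)[C@@H]1CCCN1C(=O)/C=C/c1ccncc1-c1ccc2ccccc2c1` has the entry "not determined" (no result reported) in this assay and offers no comparison. Compound 3 `O=C(O)COc1ccncc1-c1ccc2ccccc2c1` has the entry "not determined" (no result reported) in this assay and so holds no place on the scale, and compound 2 is the one further entry in the same state.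

Compound 4 `CCOC(=O)/C=C/c1ccncc1-c1ccc2ccccc2c1` is still to be measured. It carries 2-(ethoxycarbonyl)ethenyl in place of carboxymethoxy on an aromatic carbon, opposite the ring nitrogen. Counted out, the exchange reads 2-(ethoxycarbonyl)ethenyl in place of carboxymethoxy on an aromatic carbon and it is the only difference between the two structures.

Compound 3 has no number, so a step from it in this assay cannot be sized. The expectation instead rests on compound 1 at 6550 nM as the closest reference, as it too carries an ethenyl chain ending in a carbonyl. Compound 4 is expected to sit near that value, with no shift beyond the usual scatter in either direction. For compound 4 the estimated concentration is 5500 nM with an expected range from 1500 nM to 20000 nM in this measurement.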

Compound 4, concentration for 50% growth inhibition: 910 nM
Estimate against measurement, compound 4: 6.0-fold (0.78 log units) above; the whole stated range lies above it.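

In this assay, ethoxy in place of methylamino on the carbonyl carbon of the ethenyl chain gives a 7.2-fold lower number from compound 1 to compound 4 (0.86 log units; beyond the scatter) and so stronger inhibition of growth, with the rest of the structure unchanged. Among the compounds shown here, this is the first measured sign that, with the chain opposite the ring nitrogen kept, the group on its carbonyl carbon alone can move the result beyond the usual scatter; steps involving compound 2 or compound 3 cannot be read, as neither has a number. The compounds shown offer no measured explanation for this shift.

On these data alone, with one amide and one ester that carry numbers, this is a single comparison and not a trend, so it remains open whether methoxy, isopropoxy or dimethylamino on the same carbonyl carbon would follow compound 4 or compound 1. For the compounds shown here, it also remains open whether the ethenyl link itself matters, since no compound here pairs the ethoxycarbonyl group with a saturated ethyl link or a longer chain.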